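The source may hold more compounds than are shown below. What is called first, only, known or untested is meant among the compounds shown, and "the series" means these compounds.

Working notes on the series, read in a functional assay on MDA-MB-231 cells (Homo sapiens) for antiproliferative activity, read by MTT assay, with a stated time of 24 h; a lower number here means a stronger inhibitor, a higher number a weaker inhibitor. Compound 1 `Cc1cccc(NNC(=O)c2ccc(NS(=O)(=O)c3cnc(O)nc3O)cc2)c1` gives > 20000 nM, which is a limit and not a number. Compound 2 `O=C(NNc1ccc(F)cc1)c1ccc(NS(=O)(=O)c2cnc(O)nc2O)cc1` gives > 20000 nM, also a limit. Among the measured compounds shown here, compound 3 `Cc1ccccc1C(=O)NNC(=O)c1ccc(NS(=O)(=O)c2cnc(O)nc2O)cc1` gives 7040 nM, the only value so far that is not a limit. The step that the two limits leave unreadable from compound 1 to compound 2 cannot be read.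

Compound 4 `O=C(NNC(=O)c1ccccc1Cl)c1ccc(NS(=O)(=O)c2cnc(O)nc2O)cc1` differs from compound 3 as follows: chloro in place of methyl on an aromatic carbon. This places chloro in place of methyl on an aromatic carbon, ortho to a large group.

Two measured steps lead to compound 3: an at least 2.8-fold lower number from compound 1 to compound 3 (0.45 log units; beyond the scatter) and an at least 2.8-fold lower number from compound 2 to compound 3 (0.45 log units; beyond the scatter). Both exchange the whole group on an amine nitrogen, and neither exchanges methyl for chloro. For the measured compounds named here, they show only that compound 3 has a readable value, and they give no size or direction for the smaller change. The expected step is a 1.1-fold lower number from compound 3 to compound 4 (0.03 log units; within the scatter), which would be none beyond the scatter. Compound 4 is estimated at 6500 nM, with an expected range of 2800 nM to 16000 nM.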

Compound 4, half-maximal inhibitory concentration: 13900 nM
For compound 4 the middle estimate is 2.1-fold (0.33 log units) below the measured one; low and high end bracket the measured number.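

In this assay, the exchange confined to the aromatic carbon ortho to a large group reads a 2.0-fold higher number from compound 3 to compound 4 (0.30 log units; within the scatter). Methyl and chloro at this place therefore cannot be told apart, and the earlier steps, which replaced the whole group on the amine nitrogen, could not show this. With that whole-group exchange, the (2-chlorophenyl)carbonyl group reads an at least 1.4-fold lower number from compound 2 to compound 4 (0.15 log units; that floor lies within the scatter) and an at least 1.4-fold lower number from compound 1 to compound 4 (0.15 log units; that floor lies within the scatter), each a floor and not a size: the limit of > 20000 nM in this assay, at which 2 of the 4 values shown sit.

Going by these compounds, it remains open whether another group at this place, such as methoxy, an amine or a carboxylic acid, would give a step beyond the scatter. The same holds for chloro or methyl moved to another carbon of this six-membered aromatic ring.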